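Biphenyl for tert-butyl on a thiadiazole amide series

This account rests on a few compounds, and the source may have more. Where it says the series, first, only, none or still open, it means among the compounds named here.

Within the data shown here, compound 3 `COc1cccc(OC)c1C(=O)Nc1nnc(-c2ccc(C(C)(C)C)cc2)s1` is the one member of this small set for which a functional assay on the whole organism (integument) for inhibition, with Chilo suppressalis as the target, read by scintillation counting, with a stated time of 72 h (on this read-out lower numbers stand for stronger inhibition and higher numbers for weaker inhibition), gives a number: compound 3 gives 912 nM. Compound 1 `O=C(Nc1nnc(-c2ccc(Cl)cc2)s1)c1ccccc1` reaches only a limit in this assay, giving > 5010 nM. Compound 2 `O=C(Nc1nnc(-c2ccc(Cl)cc2)s1)c1ccccc1Cl` likewise stops at a limit in this assay, giving > 5010 nM. The step from compound 1 to compound 2, which introduces chloro in place of hydrogen on an aromatic carbon, is therefore a step that the two limits leave unreadable from compound 1 to compound 2; because the limit of > 5010 nM in this assay, at which 2 of the 3 values shown sit, both ends of it sit at the same limit, its size cannot be read.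

Compound 4 `COc1cccc(OC)c1C(=O)Nc1nnc(-c2ccc(-c3ccccc3)cc2)s1` is not yet measured. It differs from compound 3 by phenyl in place of tert-butyl on an aromatic carbon, placed para to a large group. Among the measured compounds shown here, no measured step concerns this position or this kind of exchange, and the only step available, from compound 1 to compound 2, is unreadable, so nothing in the data points to a change beyond the usual scatter in this assay. Compound 4 is therefore expected to give about 1000 nM, within a range of 300 nM to 3500 nM, which would mean an estimated step of a 1.1-fold higher number from compound 3 to compound 4 (0.04 log units; within the scatter) from compound 3 to compound 4.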

Compound 4, half-maximal inhibitory concentration: 195 nM
Compound 4: the middle estimate sits 5.1-fold (0.71 log units) above what was measured, and the stated range ends above it.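

In this assay, the exchange of tert-butyl for phenyl on an aromatic carbon, para to a large group, gives a 4.7-fold lower number from compound 3 to compound 4 (0.67 log units; beyond the scatter), so this position responds to a change of group. The step also shows that a six-membered aromatic ring of carbon only can take the place of tert-butyl here with a modest gain rather than a loss, with the rest of the molecule unchanged. The earlier compounds could not show anything of this kind, since the only earlier step cannot be read, both of its ends being a limit: the limit of > 5010 nM in this assay, at which 2 of the 4 values shown sit.

As far as these compounds go, whether the gain comes from the aromatic ring itself or simply from the larger count of heavy atoms stays open, and so does what an amine, a carboxylic acid or a longer chain would give at this position. It is also open whether the same exchange would bring a comparable change with the amide part of compound 1, and the numbers shown do not say why phenyl gives the lower number.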